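The compounds below may be only part of what the source reports. "The series", "measured", "known", "first", "only" and "open" are said of these compounds alone.

In an assay on isolated protein for inhibition of serine/threonine-protein kinase PLK2 (Homo sapiens), read by TR-FRET, with a stated time of 60 min (a lower number here means a stronger inhibitor, a higher number a weaker inhibitor), compound 1 `CC[C@@H]1C(=O)N(C)c2cnc(-n3ccnc3-c3ccc(F)cc3)nc2N1[C@H]1CCOC1` gives 33 nM. Compound 2 `CC[C@@H]1C(=O)N(C)c2cnc(-n3ccnc3-c3ccc(F)cc3)nc2N1C1COC1` gives 1040 nM in this assay, the highest of the two numbers; the step of a 32-fold higher number from compound 1 to compound 2 (1.50 log units; beyond the scatter) lies well beyond the scatter. Compound 3 `CC[C@@H]1C(=O)N(C)c2cnc(-n3ccnc3-c3ccc(F)cc3)nc2N1CCC(F)(F)F` differs from compound 2 by 3,3,3-trifluoropropyl in place of oxetan-3-yl on a nitrogen on an aromatic ring in a ring. Within the data shown here, no measured step covers this exchange. Among the measured compounds shown here, the single step on this ring nitrogen, a 32-fold higher number from compound 1 to compound 2 (1.50 log units; beyond the scatter), shows that the group there moves the number strongly, so a shift beyond the scatter is plausible, though its direction is not fixed by the data. Compound 3 is expected to give 300 nM, within 60 nM to 1500 nM. This estimate corresponds to an expected step of a 3.5-fold lower number from compound 2 to compound 3 (0.54 log units; beyond the scatter).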

Compound 3, half-maximal inhibitory concentration: 42 nM
Beside the measured number, compound 3's estimate is 7.1-fold (0.85 log units) above it; measured number below the stated range.
By their numbers in this assay, from the lowest: compounds 1 and 3 (each within the scatter of the next); then compound 2.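

In this assay, the large step of a 25-fold lower number from compound 2 to compound 3 (1.39 log units; beyond the scatter) shows that oxetan-3-yl is not simply replaceable at this nitrogen without consequence, since an open chain gives a much lower number. The step of a 1.3-fold higher number from compound 1 to compound 3 (0.10 log units; within the scatter) lies within the scatter, so 3,3,3-trifluoropropyl, with no ring and no hydrogen-bond acceptor, matches oxolan-3-yl here. Among these compounds, neither a ring nor a ring oxygen on this nitrogen is therefore required for the lower number, and only compound 2 stands apart. From the compounds shown here alone, whether a plain propyl chain without fluorine, an amine or a carboxylic acid would fit at this nitrogen remains open. Nothing on hand gives a cause for these steps.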